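The source may report more compounds than this note shows. Statements on the series, on what has been measured and on what is new or still open speak of the compounds shown alone.

Compound 1 `O=C(c1ccccc1)c1cccc(NS(=O)(=O)c2ccccc2)c1` and compound 2 `O=C(c1ccccc1)c1ccc(NS(=O)(=O)c2ccccc2)cc1` are built from the same atoms joined differently; the difference between the two cores is not broken down here. In an assay on CHO cells for binding affinity to integrin alpha-1 (Homo sapiens), read by WST assay, with a stated time of 2 h, tested at 50 uM (on this read-out higher numbers stand for more inhibition at the one concentration tested (going by the name of the read-out) and lower numbers for less inhibition), compound 1 gives 4%. In this assay compound 2 gives 0%; the two values lie within the scatter of each other, so nothing separates them.

Compound 3 `Cc1ccc(S(=O)(=O)Nc2ccc(C(=O)c3ccccc3)cc2)cc1` differs from compound 2 by one change, (methyl in place of hydrogen on an aromatic carbon). In this assay compound 3 gives 35%, which is a number 35 percentage points higher from compound 2 to compound 3 (beyond the scatter). Among the compounds shown this is the only measured instance of that change, so it carries all the weight of what follows.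

Compound 4 `Cc1ccc(S(=O)(=O)Nc2cccc(C(=O)c3ccccc3)c2)cc1` is not yet measured. Relative to compound 1 it carries methyl in place of hydrogen on an aromatic carbon, which is the same change as the one from compound 2 to compound 3, made at the same kind of place but on the core of compound 1 rather than that of compound 2. Among the measured compounds shown here, whether the change transfers from one core to the other is not known from the data, and the two cores give no step of their own to judge by.

For compound 4 the expected step in this assay is a number 24 percentage points higher from compound 1 to compound 4 (beyond the scatter), set somewhat smaller than the earlier step because that step, a number 35 percentage points higher from compound 2 to compound 3 (beyond the scatter), rests on a single pair and compound 1 starts from 4%. Compound 4 is therefore estimated at 28% in this assay, with a range from 5% to 52%.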

Compound 4, a percentage reported as inhibition, at one concentration (the size of the read-out at that concentration, not a potency): 34%
Compound 4: middle estimate off by 6 percentage points, on the low side; the measured number falls inside the stated range.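

In this assay, methyl in place of hydrogen on an aromatic carbon, the change that reads phenyl to 4-methylphenyl, gives a number 30 percentage points higher from compound 1 to compound 4 (beyond the scatter). Set beside the earlier step, the change carries from one core to the other with no difference in size that can be separated from the scatter: the same change on two cores in this assay, a number 35 percentage points higher (beyond the scatter) from compound 2 to compound 3 and a number 30 percentage points higher (beyond the scatter) from compound 1 to compound 4, 5 percentage points apart, within the scatter of two such steps This agreement rests on only two pairs, each read at one concentration, so it shows that the step transfers between these two cores on this read-out, but it does not give a potency, does not explain the step, and does not extend to any other core.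

The compounds shown leave open whether the step belongs to methyl in particular or would also appear with another group at the same place, such as ethyl, a longer chain, methoxy, chlorine or a carboxylic acid. They also leave open what the same methyl would do elsewhere on that ring or on the benzoyl phenyl ring, and whether the two cores, which so far show no separable difference with or without the methyl, would stay together under other changes.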